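Benzoyl for Ethoxycarbonyl at Two Different Carbonyl Carbons

The compounds below may be only part of what the source reports. "The series", "measured", "known", "first", "only" and "open" are said of these compounds alone.

Measured compounds:
compound 1, `CCOC(=O)c1cnc(N(C(=O)c2ccccc2)N2C(=O)C=C(C)C2=O)nc1C(F)(F)F`: 830 nM
compound 2, `CCOC(=O)c1cnc(N(C(=O)OCC)N2C(=O)C=C(C)C2=O)nc1C(F)(F)F`: 380 nM
compound 3, `CCOC(=O)c1cnc(NN2C(=O)C=C(C)C2=O)nc1CC`: 400 nM

In a functional assay on Jurkat cells (Homo sapiens) for inhibition (on this read-out higher numbers stand for weaker inhibition and lower numbers for stronger inhibition), compound 1 gives 830 nM, compound 2 gives 380 nM and compound 3 gives 400 nM. Compound 2 and compound 1 share one core and differ in a single place: phenyl in place of ethoxy on a carbonyl carbon. That change produced a 2.2-fold higher number from compound 2 to compound 1 (0.34 log units; beyond the scatter). Compound 3 and compound 2 lie within the scatter of each other, and how the core of compound 3 differs from that of compound 2 is not broken down here.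

Compound 4, `CCc1nc(NN2C(=O)C=C(C)C2=O)ncc1C(=O)c1ccccc1`, has not yet been measured in this assay. It differs from compound 3 in one place: phenyl in place of ethoxy on a carbonyl carbon. For the measured compounds named here, this is the same kind of change as the one between compound 2 and compound 1, but not the same: in the earlier pair the carbonyl carbon's other neighbour is an amide-type nitrogen, whereas in the new pair it is an aromatic carbon. Because the same kind of change gave a 2.2-fold higher number from compound 2 to compound 1 (0.34 log units; beyond the scatter), compound 4 is expected to give a modestly higher number than compound 3. The step this expectation implies is a 1.8-fold higher number from compound 3 to compound 4 (0.24 log units; within the scatter), set beside the earlier one with wide bounds, since the surroundings of the carbonyl carbon differ. In this assay compound 4 is estimated at 700 nM, expected between 250 nM and 2000 nM.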

Compound 4, half-maximal inhibitory concentration: 650 nM
For compound 4 the middle estimate is 1.1-fold (0.03 log units) above the measured one, and the stated range covers the measured number.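

Putting benzoyl in place of ethoxycarbonyl on the core of compound 3 gave, in this assay, a 1.6-fold higher number from compound 3 to compound 4 (0.21 log units; within the scatter), so on this core the step cannot be told apart from the usual variation between repeated measurements. Set beside the earlier pair, the two steps do not differ: the same change on two cores in this assay, a 2.2-fold higher number (0.34 log units; beyond the scatter) from compound 2 to compound 1 and a 1.6-fold higher number (0.21 log units; within the scatter) from compound 3 to compound 4, 1.3-fold (0.13 log units) apart, within the scatter of two such steps. For the compounds shown here, nothing in these two pairs speaks against carrying the change from a carbonyl carbon bound to an amide-type nitrogen over to one bound to an aromatic carbon, but two pairs do not make a rule for the series, and since only the step on the earlier core lies beyond the scatter, a real difference between compound 3 and compound 4 remains unshown.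

The compounds shown leave open how the same carbonyl carbon would read with an amine in its place of ethoxy or phenyl, or with a longer chain such as butoxy, and whether a substituted phenyl, for instance one bearing a methoxy group, would follow the plain phenyl. They also leave open whether the step would hold on further cores, as the pairs here cover only two.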